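Chalcone series: cytotoxicity in macrophage cells, third analogue

The source may hold more compounds than are shown below. What is called first, only, known or untested is meant among the compounds shown, and "the series" means these compounds.

Of the compounds shown here, two have been measured so far. Compound 1 `COc1ccc(/C=C/C(=O)c2ccc(OC)c(OC)c2)cc1` and compound 2 `COc1ccc(C(=O)/C=C/c2ccc(OC)c(OC)c2)c(O)c1` were run in an ADME assay on RAW264.7 cells (Mus musculus) for cytotoxicity, read by MTT assay, with a stated time of 24 h, tested at 2.5 ug/mL; on this read-out higher numbers stand for a weaker effect at the one concentration tested and lower numbers for a stronger effect. In this assay compound 1 gives 93.1%. In this assay compound 2 gives 92.6%. The two numbers lie within the scatter of one another, so on the figures shown compound 2 and compound 1 cannot be told apart; both show only a weak effect at the single concentration tested. For the measured compounds named here, no pair of measured compounds differing in one place exists, so no step between measured compounds is available.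

Compound 3 `COc1ccc(C(=O)/C=C/c2ccc(OC)c(OC)c2OC)c(O)c1` is the next analogue and has not been measured. It differs from compound 2 in one place: methoxy in place of hydrogen on an aromatic carbon. Given that compound 2 shows 92.6%, and that compound 1 with 93.1% sits in the same range, the step in this assay from compound 2 to compound 3 is expected to be none beyond the scatter, that is, the expected step is a number 2.6 percentage points lower from compound 2 to compound 3 (within the scatter). Compound 3 in this assay is therefore estimated at 90%, with a range from 78% to 99%.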

Compound 3, a percentage reported as activity, at one concentration (the size of the read-out at that concentration, not a potency): 96.6%
Beside the measured number, compound 3's estimate is 6.6 percentage points below it; measured number inside the range.
By their numbers in this assay, from the lowest: compounds 2, 1 and 3 (each within the scatter of the next).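

For the compounds shown here, this is the first step between measured compounds differing in one place: in this assay, methoxy in place of hydrogen on an aromatic carbon gives a number 4 percentage points higher from compound 2 to compound 3 (within the scatter) and so leaves the two compounds indistinguishable on this read-out. The position concerned lies on a six-membered aromatic ring of carbon only, ortho to a large group, ortho to a methoxy group and meta to a methoxy group, and this crowded substitution pattern still gives compound 3 only a weak effect at the single concentration tested. Nothing available on these compounds speaks to the reason for this result.

Going by these compounds alone, whether a different group at this same position, such as an amine, a carboxylic acid or a longer alkoxy chain, would give a step beyond the scatter remains open, since methoxy is the only group compared with hydrogen here. Also open is how compound 2 and compound 3 behave at higher concentrations, where a single-concentration read-out offers no guide and no potency can be inferred from the figures shown.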